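Cyclohexyl for cyclopropyl on the enol ether series

This account rests on a few compounds, and the source may have more. Where it says the series, first, only, none or still open, it means among the compounds named here.

Of the compounds shown here, three have been measured in a functional assay on SW1573 cells (Homo sapiens) for antiproliferative activity, read by sulforhodamine B assay, with a stated time of 48 h; a higher number here means a weaker inhibitor of growth, a lower number a stronger inhibitor of growth. Compound 1 `COC(=O)C#CC(O/C=C/C(=O)OC)C1CC1` gives 1800 nM and stands at the low end of the three numbers. Compound 3 `CCCCCCCCCCC(C#CC(=O)OC)O/C=C/C(=O)OC` gives 2000 nM, which sits within the scatter of compound 1, so the two show no difference of note. Compound 2 `CC(C)C(C#CC(=O)OC(C)(C)C)O/C=C/C(=O)OC(C)(C)C` gives 4800 nM, a higher number than compound 1 and beyond the scatter; compound 2 also carries tert-butyl esters rather than methyl esters, so its gap to compound 1 cannot be tied to one change.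

Compound 4 `COC(=O)C#CC(O/C=C/C(=O)OC)C1CCCCC1` has not yet been measured. It differs from compound 1 in one place: cyclohexyl in place of cyclopropyl on a saturated chain carbon bound to an oxygen on an unsaturated carbon and a triple-bonded carbon. The values of compound 1 and compound 3 show that a small ring and a long chain on this carbon give numbers within the scatter of each other, so no step beyond the scatter is expected for a six-membered ring either. The step from compound 1 to compound 4 is expected to be a 1.1-fold higher number from compound 1 to compound 4 (0.05 log units; within the scatter). Compound 4 is estimated at 2000 nM, with a range from 900 nM to 4500 nM.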

Compound 4, concentration for 50% growth inhibition: 2100 nM
The estimate for compound 4 lay 1.1-fold (0.02 log units) below the measured number; measured number inside the range.
By their numbers in this assay, from the lowest: compounds 1, 3 and 4 (each within the scatter of the next); then compound 2.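

Within the data shown here, on a saturated chain carbon bound to an oxygen on an unsaturated carbon and a triple-bonded carbon, cyclohexyl in place of cyclopropyl is the first single-place change that can be read in this assay, and it gives a 1.2-fold higher number from compound 1 to compound 4 (0.07 log units; within the scatter). This position therefore accepts the six-membered ring, with 6 heavy atoms entering for 3, with no change that can be told from the scatter. No measured evidence on hand accounts for this step.

As far as these compounds go, it remains open whether phenyl, or a chain ending in an amine, on this carbon would leave the number equally unmoved. The compounds shown also cannot separate the effect of tert-butyl esters from that of the group on this carbon, since compound 2 differs from the others in more than one place.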